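The source may hold more compounds than are shown below. What is called first, only, known or untested is meant among the compounds shown, and "the series" means these compounds.

Among the measured compounds shown here, compound 2 `NC(=O)c1ccc2[nH]c(-c3ccc(OCCCN4CCCCC4)cc3)nc2c1` is the only compound in this small set with a reading to start from. Going by these compounds, in a physicochemical assay for solubility, with a stated time of 3 days, at pH 7 (on this read-out lower numbers stand for lower solubility and higher numbers for higher solubility), compound 2 gives > 400000 nM, which is a limit of the assay and not a number, so its exact position is unknown. Compound 1 `CN1CCC(Oc2ccc(-c3nc4cc(C(N)=O)ccc4[nH]3)cc2)C1` shares the core, but in this assay compound 1 has "not determined" (no result reported), so it offers no comparison.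

Compound 3 `CN1CCC(Oc2ccc(-c3nc4cc(C(N)=O)ccc4[nH]3)cc2)CC1`, still to be measured, has 1-methylpiperidin-4-yl in place of the 3-(piperidin-1-yl)propyl of compound 2, on an oxygen on an aromatic ring (1-methylpiperidin-4-yl in place of 3-(piperidin-1-yl)propyl on an oxygen on an aromatic ring). Both groups hold one six-membered non-aromatic ring with 1 hetero atom, and the entering group has fewer heavy atoms. For the measured compounds named here, no measured pair shows what a change of this kind does. The expectation therefore rests only on compound 2, whose limit is > 400000 nM. The expected size of the change, a number no higher from compound 2 to compound 3 (the limit leaves the size open), is none beyond the usual scatter, in either direction. For compound 3 the estimated value is 400000 nM, with an expected range from 200000 nM to 800000 nM.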

Compound 3, solubility: > 400000 nM
Compound 3 was reported as a limit; the forecaster's own chance of this, stated with the estimate: 65%; the middle value lies on the limit itself.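

No step can be read from compound 2 to compound 3, since this assay gives a limit and not a number for each of them: the limit of > 400000 nM in this assay, at which 2 of the 3 values shown sit. The compounds shown leave open how far beyond this limit the solubility of each lies, and whether putting 1-methylpiperidin-4-yl in place of 3-(piperidin-1-yl)propyl changes it at all.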